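A fourth halogenated sulfonamide awaits its growth-inhibition reading

This account rests on a few compounds, and the source may have more. Where it says the series, first, only, none or still open, it means among the compounds named here.

Measured so far in a functional assay on cells (leukaemia cell line, Homo sapiens) for inhibition, read by sulforhodamine B assay, with a stated time of 48 h (on this read-out lower numbers stand for stronger inhibition of growth and higher numbers for weaker inhibition of growth), are these three compounds:
Compound 1 `O=S(=O)(Nc1ccc(Cl)cc1Cl)c1ccc(-c2cnc(C3CC3)o2)cc1` gives 74500 nM in this series
Compound 2 `O=S(=O)(Nc1ccc(F)c(Cl)c1)c1ccc(-c2cnc(C3CC3)o2)cc1` gives 73700 nM in this series
Compound 3 `O=S(=O)(Nc1ccc(Cl)c(F)c1)c1ccc(-c2cnc(C3CC3)o2)cc1` gives 63000 nM in this series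

Compound 3 stands level with the other two, and its value of 63000 nM cannot be told apart from theirs. The next structure, compound 4 `O=S(=O)(Nc1cc(Cl)ccc1Cl)c1ccc(-c2cnc(C3CC3)o2)cc1` and not yet measured, carries 2,5-dichlorophenyl in place of 4-chloro-3-fluorophenyl on a sulfonamide nitrogen with the shared core unchanged.

Within the data shown here, three measured steps bear on this swap, since each exchanges one halogenated phenyl group for another at that same nitrogen. They are a 1.0-fold lower number from compound 1 to compound 2 (0.00 log units; within the scatter) and a 1.2-fold lower number from compound 1 to compound 3 (0.07 log units; within the scatter) and a 1.2-fold lower number from compound 2 to compound 3 (0.07 log units; within the scatter) and all of them lie within the scatter. The second is the closest parallel, as it links a dichlorophenyl compound with compound 3. Among the measured compounds shown here, no measured compound carries 2,5-dichlorophenyl itself, so this remains an extrapolation.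

On this evidence, no shift beyond the scatter is expected in this assay and the estimated change is a 1.1-fold higher number from compound 3 to compound 4 (0.05 log units; within the scatter) for this swap. Compound 4 is estimated at 70000 nM with 40000 nM to 120000 nM as the expected range.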

Compound 4, concentration for total growth inhibition: > 100000 nM
Compound 4: only a limit was reported; the forecaster's own chance of this, stated with the estimate: 10%; middle value at least 1.4-fold (0.15 log units) away from the limit.
By their numbers in this assay, from the lowest: compounds 3, 2 and 1 (each within the scatter of the next). At a limit, above all of these: compound 4.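

In this assay compound 4 is the only one of the four to give a limit rather than a number: the limit of > 100000 nM in this assay, at which 1 of the 4 values shown sits. Only floors can be read from this limit: an at least 1.5-fold higher number from compound 3 to compound 4 (0.20 log units; that floor lies within the scatter), an at least 1.3-fold higher number from compound 2 to compound 4 (0.13 log units; that floor lies within the scatter) and an at least 1.3-fold higher number from compound 1 to compound 4 (0.12 log units; that floor lies within the scatter), and each of these floors lies within the scatter, so they do not establish a real difference between 2,5-dichlorophenyl and the other groups. Among these compounds, what is new is that the three other halogenated phenyl groups on a sulfonamide nitrogen gave numbers that cannot be told apart, whereas 2,5-dichlorophenyl at the same place gives no number, which leaves the true size of this change unknown, and the even picture from the earlier compounds cannot be extended to it.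

The compounds shown leave open how far beyond the limit compound 4 lies, and whether any group at this place can separate from the others by more than the scatter. They also leave open how a phenyl ring carrying a methoxy group, an amine or a carboxylic acid in place of the halogens would read on this measure.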